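Triazole for Ethoxy on the Indane Side Chain

The source may report more compounds than this note shows. Statements on the series, on what has been measured and on what is new or still open speak of the compounds shown alone.

Measured so far:
Compound 1, `CS(=O)(=O)Nc1c(Cl)ccc2c1CCCC2c1ncc[nH]1`, gives 64%.
Compound 2, `CCOCc1cccc2c1CCC2c1ncc[nH]1`, gives 64%.
Compound 3, `COCc1cc(F)cc2c1CCC2c1ncc[nH]1`, gives 87%.

In a functional assay on CHO cells for agonist activity at Alpha-1A adrenergic receptor (Homo sapiens), read by fluorescence and calcium flux (a higher number here means a larger maximal response, a lower number a smaller maximal response), compound 2 gives 64%, level with compound 1 at the digits shown and together the lowest of the three; compound 3 sits well above both, a gap beyond the usual scatter.

Compound 4, `c1cc(Cn2ccnn2)c2c(c1)C(c1ncc[nH]1)CC2`, has not yet been measured. It differs from compound 2 in one place: 1H-1,2,3-triazol-1-yl in place of ethoxy on a saturated chain carbon bound to an aromatic carbon. Among the measured compounds shown here, no measured pair shows this exchange, so its effect is unknown; the expected step from compound 2 to compound 4 is a number 2 percentage points lower from compound 2 to compound 4 (within the scatter), small and of uncertain direction, likely within the scatter. Compound 4 is therefore estimated to give 62%, ranging from 38% to 86%.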

Compound 4, largest response reached (Emax), in percent of the reference or control that the assay uses: 62%
Beside the measured number, compound 4's estimate shows no gap at the digits printed; measured number inside the range.
By their numbers in this assay, from the lowest: compounds 4, 1 and 2 (each within the scatter of the next); then compound 3.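

In this assay, putting 1H-1,2,3-triazol-1-yl in place of ethoxy on this saturated chain carbon bound to an aromatic carbon gives a number 2 percentage points lower from compound 2 to compound 4 (within the scatter). This single pair shows that the position accepts a five-membered aromatic ring as well as an open ether chain, with the maximal response staying level. No other data here bear on why the two groups match.

Still open, on these data alone, is whether an amine or a carboxylic acid on the same carbon would keep this response. A phenyl ring there would test whether the ring nitrogens of the triazole matter.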